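The compounds below may be only part of what the source reports. "The series", "measured", "known", "first", "only" and "open" are said of these compounds alone.

Compound 2 `NC(=O)CC[C@H](NC(=O)CN(c1ncnc2c1ncn2C1CCCCO1)C1CC1)C(=O)OCc1ccccc1` was tested in a functional assay on the whole organism (Tail, strain ICR) with Mus musculus as the target, in the tail flick test, with a stated time of 60 min, at a dose of 25 umol/kg by the oral route (on this read-out higher numbers stand for a stronger effect at the one dose given and lower numbers for a weaker effect), where compound 2 gives 39.4%. For the measured compounds named here, the only other measured compound, compound 1 `C[C@@H](O)[C@H](NC(=O)CN(c1nc(Cl)nc2[nH]cnc12)C1CC1)C(=O)O`, differs from it in several places at once; in this assay compound 1 gives 30.1%, a number that lies within the scatter of the one for compound 2, so the two cannot be told apart on this read-out.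

Compound 3 `CC(C)C[C@H](NC(=O)CN(c1ncnc2c1ncn2C1CCCCO1)C1CC1)C(=O)OCc1ccccc1` has not yet been measured in this assay. It differs from compound 2 in one place: isopropyl in place of carbamoylmethyl on a saturated chain carbon, two bonds along the chain from an amide-type nitrogen and a carbonyl carbon. A group carrying one hydrogen-bond donor and one hydrogen-bond acceptor leaves, and a group with neither enters, while the rest of the molecule stays as in compound 2.

Going by the values given here, no pair of measured compounds differing in a single place is available, so nothing shows how large a step such a swap brings in this assay. The only hint at hand is that compound 1 and compound 2, despite differing widely, give numbers within the scatter of each other. The step from compound 2 to compound 3 is therefore expected to be small, a number 1.4 percentage points lower from compound 2 to compound 3 (within the scatter), with no clear direction beyond the scatter. Compound 3 is estimated at 38%, within a range from 15% to 60%.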

Compound 3, a percentage reported as activity, at one dose (the size of the read-out at that dose, not a potency): 34.2%
Beside the measured number, compound 3's estimate is 3.8 percentage points above it, within the range that was stated.
By their numbers in this assay, from the lowest: compounds 1, 3 and 2 (each within the scatter of the next).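

For the compounds shown here, this is the first pair here that differs in one place only, and in this assay putting isopropyl in place of carbamoylmethyl on this saturated chain carbon gives a number 5.2 percentage points lower from compound 2 to compound 3 (within the scatter) and so no step that can be told from the usual spread of repeated measurements. At this position, a group with one hydrogen-bond donor and one hydrogen-bond acceptor can therefore be exchanged for a group with neither, and this read-out at its single dose does not separate the two compounds. Nothing measured here bears on why the swap leaves the two numbers within the scatter of each other.

Going by these compounds, whether this holds for other groups at the same carbon stays open, since an amine, a carboxylic acid or a longer chain there could give a step beyond the scatter or none at all. A single pair also cannot show whether the same swap would read the same way on a different core, such as the core of compound 1, or at a different dose.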